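The compounds below may be only part of what the source reports. "The series", "measured", "known", "first", "only" and "open" are said of these compounds alone.

Working notes on the series.

Compound 1 `C[C@H](Nc1cc(F)c(S(=O)(=O)Nc2nccs2)cc1Cl)c1ccccc1` gives 20 nM in an assay on HEK293 cells for inhibition of SCN8A/SCN1B (Homo sapiens), read by patch clamp, with a stated time of 20 min; on this read-out lower numbers stand for stronger inhibition and higher numbers for weaker inhibition. Compound 2 `COC[C@H](Nc1cc(F)c(S(=O)(=O)Nc2nccs2)cc1Cl)c1ccccc1` gives 40 nM in this assay, and the step of a 2.0-fold higher number from compound 1 to compound 2 (0.30 log units; within the scatter) lies within the scatter. Compound 3 `C[C@H](Nc1cc(F)c(S(=O)(=O)Nc2cscn2)cc1Cl)c1ccccc1` gives 650 nM, the highest number of the three measured, with the step of a 33-fold higher number from compound 1 to compound 3 (1.51 log units; beyond the scatter) well beyond the scatter.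

The next compound, compound 4 `O=S(=O)(Nc1cscn1)c1cc(Cl)c(NCc2cc(F)ccc2F)cc1F`, carries the same sulfonamide part as compound 3 and differs only at the aromatic nitrogen: 2,5-difluorobenzyl in place of 1-phenylethyl on a nitrogen on an aromatic ring. Going by the values given here, no measured step covers this exchange. Among the compounds with values here, the only step that touches the same part of the molecule is the one from compound 1 to compound 2, a change on the saturated chain carbon, and it stayed within the scatter. On these data alone, on that basis the expected step of a 1.2-fold higher number from compound 3 to compound 4 (0.09 log units; within the scatter) is not beyond the scatter, in no clear direction, and the range is kept wide because the change is untested. Compound 4 is therefore estimated at 800 nM in this assay, between 250 nM and 2500 nM.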

Compound 4, half-maximal inhibitory concentration: 450 nM
Estimate against measurement, compound 4: 1.8-fold (0.25 log units) above; measured number inside the range.
By their numbers in this assay, from the lowest: compounds 1 and 2 (each within the scatter of the next); then compounds 4 and 3 (each within the scatter of the next).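

With the 1,3-thiazol-4-yl sulfonamide held fixed, replacing the whole 1-phenylethyl group with 2,5-difluorobenzyl on the nitrogen gives, in this assay, a 1.4-fold lower number from compound 3 to compound 4 (0.16 log units; within the scatter). The earlier step changed only a saturated chain carbon, whereas this exchange removes the defined stereocentre and brings in two fluorine atoms, and the number still does not move beyond the scatter, so in this sulfonamide series the exchange is tolerated without a readable change. Nothing shown gives a reason for this result.

On these data alone, it remains open whether the same exchange would stay within the scatter with the 1,3-thiazol-2-yl sulfonamide of compound 1. Also open, as far as these compounds go, is how this nitrogen would respond to a group of another kind, such as an aminoethyl or carboxymethyl chain in place of the benzyl.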